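The source may hold more compounds than are shown below. What is called first, only, known or untested is meant among the compounds shown, and "the series" means these compounds.

In a functional assay on MT4 cells (Homo sapiens) for cytotoxicity, with a stated time of 4 days (a higher number here means that more compound is tolerated, a lower number that less compound is tolerated), compound 1 `OC[C@H]1O[C@@H](n2cnc3c(Cn4ccc5ccccc54)ncnc32)[C@H](O)[C@@H]1O` gives 45000 nM and compound 2 `CSCc1ncnc2c1ncn2[C@@H]1O[C@H](CO)[C@@H](O)[C@H]1O` gives 32000 nM. Going by the values given here, the only measured step between them is a 1.4-fold lower number from compound 1 to compound 2 (0.15 log units; within the scatter), so compound 2 stands level with compound 1 on these numbers. Compound 3 `OCCSCc1ncnc2c1ncn2[C@@H]1O[C@H](CO)[C@@H](O)[C@H]1O` changes compound 2 in one place: hydroxymethyl in place of hydrogen on a saturated chain carbon bound to a sulfur. This puts hydroxymethyl in place of hydrogen on a saturated chain carbon bound to a sulfur, turning methylsulfanyl into (2-hydroxyethyl)sulfanyl. The measured step bears on this only indirectly: it replaced 1H-indol-1-yl with methylsulfanyl, and that exchange gave only a 1.4-fold lower number from compound 1 to compound 2 (0.15 log units; within the scatter). Among the compounds with values here, no measurement yet shows the effect of adding hydroxymethyl here, so no direction can be favoured and no shift beyond the scatter is expected. The estimated change is a 1.1-fold higher number from compound 2 to compound 3 (0.04 log units; within the scatter). For compound 3 the expected value is 35000 nM, with an estimated range of 15000 nM to 80000 nM.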

Compound 3, half-maximal cytotoxic concentration: > 100000 nM
Compound 3 ended at the assay's limit; the forecaster's own chance of this, stated with the estimate: 15%; at least 2.8-fold (0.45 log units) between middle value and limit.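

At this place, on a saturated chain carbon bound to a sulfur, a small addition does register in this assay: hydroxymethyl in place of hydrogen gives an at least 3.1-fold higher number from compound 2 to compound 3 (0.49 log units; beyond the scatter). The (2-hydroxyethyl)sulfanyl group also separates from 1H-indol-1-yl, with an at least 2.2-fold higher number from compound 1 to compound 3 (0.34 log units; beyond the scatter), whereas methylsulfanyl and 1H-indol-1-yl did not separate, with a 1.4-fold lower number from compound 1 to compound 2 (0.15 log units; within the scatter). The value for compound 3 is a limit of the assay: the limit of > 100000 nM in this assay, at which 1 of the 3 values shown sits.

The compounds shown leave open whether the same step would appear with a plain ethyl group, which lacks the oxygen, or with a 2-aminoethyl group, a carboxylic acid or a longer chain ending in a hydroxyl group at this place. They also do not tell what causes the step.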